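Aryloxyacetamide series: phenyl for sec-butyl on the amide nitrogen

This account rests on a few compounds, and the source may have more. Where it says the series, first, only, none or still open, it means among the compounds named here.

Measured compounds:
compound 1, `CCN(Cc1cc[nH]c1)C(=O)COc1ccc(C)cc1` — 21800 nM
compound 2, `CCC(C)N(Cc1cccs1)C(=O)COc1ccc(C)cc1` — 2000 nM

In an assay on HEK293 cells for agonist activity at transient receptor potential cation channel subfamily M member 8 (Homo sapiens), read by fluorescence and calcium flux, with a stated time of 15 min (a lower number here means that less compound is needed, a higher number that more compound is needed for the effect), compound 1 gives 21800 nM. Among the compounds with values here, compound 2 gives 2000 nM, the lowest of the two numbers so far, and its gap to compound 1 lies beyond the scatter. The two compounds differ in several places at once, so their pair says nothing about any single change.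

Compound 3, `Cc1ccc(OCC(=O)N(Cc2cccs2)c2ccccc2)cc1`, has not been measured. It differs from compound 2 in one place: phenyl in place of sec-butyl on an amide-type nitrogen. Within the data shown here, no pair of measured compounds shares this change, so there is no step on record to lean on. Among the measured compounds shown here, the group that leaves and the group that enters carry no donors or acceptors and no charge, and the only anchor is compound 2 with its 2000 nM. The step from compound 2 to compound 3 is expected to be small, a 1.3-fold lower number from compound 2 to compound 3 (0.12 log units; within the scatter), not beyond the scatter in either direction. Compound 3 is therefore expected to give about 1500 nM in this assay, within a range of 300 nM to 8000 nM.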

Compound 3, half-maximal effective concentration: 23 nM
Beside the measured number, compound 3's estimate is 65-fold (1.81 log units) above it, and the stated range ends above it.
By their numbers in this assay, from the lowest: compound 3; then compound 2; then compound 1.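

Within the data shown here, compounds so far differed in several places at once, so this is the first step that ties a change in this assay to one position: on the amide-type nitrogen, phenyl in place of sec-butyl gives an 87-fold lower number from compound 2 to compound 3 (1.94 log units; beyond the scatter), beyond the scatter. The size of this step shows that the number is highly sensitive to the group at this nitrogen, even though neither the leaving nor the entering group carries hydrogen-bond donors, acceptors or a net charge; on paper, the swap replaces an open chain with a six-membered aromatic ring of carbon only. No measurement in hand accounts for a step of this size.

The compounds shown leave open whether the gain belongs to the aromatic ring or to any ring at this nitrogen, a question that cyclohexyl in the same place would address directly. They also leave open how far the phenyl tolerates change, for instance a fluorine, a methoxy group or a carboxylic acid on it, or a benzyl group in its stead.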